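A few compounds are considered here, and "the series" means these few. Any claim that something is new, unique, unknown or untested is made for them only; others in the source may bear on it.

Measured so far in a functional assay on PC-3 cells (Homo sapiens) for inhibition, read by sulforhodamine B assay, with a stated time of 48 h, tested at 50 uM; a higher number here means more inhibition of growth at the concentration tested, a lower number less inhibition of growth:
- Compound 1 `COc1ccc([C@@H]2C/C(=N/OCc3cn(-c4ccc(Cl)cc4C)nn3)c3cc(CC=C(C)C)c(OC)cc3O2)cc1`: 49%
- Compound 2 `COc1cc2c(cc1CC=C(C)C)C(=O)C[C@@H](c1ccc(Oc3cccc([N+](=O)[O-])c3)cc1)O2`: 21%
- Compound 3 `COc1ccc([C@@H]2C/C(=N/OCc3cn(-c4ccc(NC(=O)c5ccccc5)cc4)nn3)c3cc(CC=C(C)C)c(OC)cc3O2)cc1`: 22%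

Compound 1 stands highest of these three numbers. Compound 2 and compound 3 both lie lower, each by a gap beyond the usual scatter.

Compound 4 `COc1ccc([C@@H]2C/C(=N/OCc3cn(-c4cccnc4Cl)nn3)c3cc(CC=C(C)C)c(OC)cc3O2)cc1` has not yet been measured. It carries 2-chloropyridin-3-yl in place of the 4-chloro-2-methylphenyl of compound 1, on an aromatic nitrogen of a five-membered aromatic ring with 3 nitrogen (2-chloropyridin-3-yl in place of 4-chloro-2-methylphenyl on an aromatic nitrogen).

Within the data shown here, no pair of measured compounds differs in one place only, so the data offer no direct guide to this change. Compound 3, which has a different group on that aromatic nitrogen, gives 22%, and that value suggests compound 1 need not hold its number when the group changes. A moderate downward step in this assay is therefore expected, though one that may end up little beyond the scatter. The estimated change is a number 15 percentage points lower from compound 1 to compound 4 (beyond the scatter). Compound 4 is expected at 34%, with an estimated range from 17% to 52%.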

Compound 4, percent growth inhibition at one concentration: 44%
Compound 4: the middle estimate sits 10 percentage points below what was measured; the measured number falls inside the stated range.
By their numbers in this assay, from the lowest: compounds 2 and 3 (each within the scatter of the next); then compounds 4 and 1 (each within the scatter of the next).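

In this assay, 2-chloropyridin-3-yl in place of 4-chloro-2-methylphenyl on an aromatic nitrogen of the five-membered aromatic ring with 3 nitrogen gives a number 5 percentage points lower from compound 1 to compound 4 (within the scatter). Among these compounds, this is the first comparison at this position that changes one place only, and it shows that a six-membered aromatic ring with 1 hetero atom and 1 hydrogen-bond acceptor can replace a ring of carbon only without a change beyond the scatter. No measurement shown here accounts for this result.

Going by these compounds, both groups carry a chlorine, so it remains open what a ring bearing an amine or a carboxylic acid in place of that chlorine would give at this position. On these data alone, whether an unsubstituted phenyl would give a similar number also remains open.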